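The source may report more compounds than this note shows. Statements on the series, on what has been measured and on what is new or still open speak of the compounds shown alone.

Of the compounds shown here, three have been measured in a functional assay on MDA-MB-231 cells (Homo sapiens) for inhibition, read by sulforhodamine B assay, tested at 10 uM; on this read-out higher numbers stand for more inhibition at the one concentration tested (going by the name of the read-out) and lower numbers for less inhibition. Compound 1 `CN1CCN(c2ccc(C3=NN(C(=O)CCCl)C(c4ccc(N(C)C)cc4)C3)cc2)CC1` gives 2.4%, and compound 2 `CN1CCN(c2ccc(C3=NN(C(=O)/C=C/c4ccccc4)C(c4ccc(N(C)C)cc4)C3)cc2)CC1` gives 35.9%; the step of a number 33.5 percentage points higher from compound 1 to compound 2 (beyond the scatter) is the only large one among the three. Compound 3 `CN(C)c1ccc(C2CC(c3ccc(-n4cncn4)cc3)=NN2C(=O)CCCl)cc1` gives 3.7%, and the step of a number 1.3 percentage points higher from compound 1 to compound 3 (within the scatter) shows that the exchange on the aromatic carbon made no difference worth noting. On these numbers compound 3 stands second highest of the three, with compound 1 nearest to it and within the scatter, and compound 2 furthest from it and beyond the scatter.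

Compound 4 `CN(C)c1ccc(C2CC(c3ccc(-n4cncn4)cc3)=NN2C(=O)c2cc(Cl)cc(Cl)c2)cc1` differs from compound 3 at the carbonyl carbon: 3,5-dichlorophenyl in place of 2-chloroethyl on a carbonyl carbon. For the measured compounds named here, the one measured step that bears on this place is the one from compound 1 to compound 2, where an aromatic-bearing group replaced the same 2-chloroethyl on the carbonyl carbon and inhibition rose strongly. The group entering compound 4 is also aromatic, though not the same group, so a rise is expected, with wide uncertainty. Compound 4 is therefore estimated at 25%, in a range from 5% to 50%, which would mean an expected step of a number 21.3 percentage points higher from compound 3 to compound 4 (beyond the scatter).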

Compound 4, a percentage reported as inhibition, at one concentration (the size of the read-out at that concentration, not a potency): 9.4%
Beside the measured number, compound 4's estimate is 15.6 percentage points above it; the range from low to high includes it.
By their numbers in this assay, from the lowest: compounds 1, 3 and 4 (each within the scatter of the next); then compound 2.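

Swapping 2-chloroethyl for 3,5-dichlorophenyl on the carbonyl carbon, a change that brings in a six-membered aromatic ring, gives a number 5.7 percentage points higher from compound 3 to compound 4 (within the scatter) in this assay, so on this core the ring and its two chlorines do not move the read-out beyond the usual scatter. The earlier change at this same place, a number 33.5 percentage points higher from compound 1 to compound 2 (beyond the scatter), had suggested that this position could respond strongly, but the new step shows that replacing 2-chloroethyl with an aromatic group does not by itself bring such a rise, and the two steps also differ in the entering group and in the 4-methylpiperazin-1-yl or 1H-1,2,4-triazol-1-yl group that the compounds carry. Nothing available explains why the two steps differ in size.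

The compounds shown leave open whether the large step belongs to 2-phenylethenyl itself or depends on the 4-methylpiperazin-1-yl group, a question that only 2-phenylethenyl on the 1H-1,2,4-triazol-1-yl compound could settle. They also leave open how a plain phenyl without chlorine, or a chain ending in an amine, would read on the same carbonyl carbon.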